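Aryl variation at the saturated ring carbon: cytotoxicity notes

This account rests on a few compounds, and the source may have more. Where it says the series, first, only, none or still open, it means among the compounds named here.

Measured so far:
compound 1, `COc1cc(N2C(N)=C(C#N)C(c3c(O)ccc4ccccc34)C3=C2CC(C)(C)CC3=O)cc(OC)c1OC`: 10%
compound 2, `COc1cc(N2C(N)=C(C#N)C(c3ccccc3Cl)C3=C2CC(C)(C)CC3=O)cc(OC)c1OC`: 15%
compound 3, `COc1cc(N2C(N)=C(C#N)C(c3cccs3)C3=C2CC(C)(C)CC3=O)cc(OC)c1OC`: 10%

In a functional assay on Ehrlich cells (Mus musculus) for cytotoxicity, tested at 25 ug/mL (a higher number here means a stronger effect of the compound at the concentration tested, a lower number a weaker effect), compound 3 stands level with compound 1 at the digits shown, the two together being the lowest of the three numbers; the step of no change at the digits printed from compound 1 to compound 3 (within the scatter) and the step of a number 5 percentage points lower from compound 2 to compound 3 (within the scatter) are both within the scatter.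

Compound 4, `COc1cc(N2C(N)=C(C#N)C(c3ccc(O)cc3)C3=C2CC(C)(C)CC3=O)cc(OC)c1OC`, differs from compound 3 by 4-hydroxyphenyl in place of thiophen-2-yl on a saturated ring carbon. Among the compounds with values here, the steps that bear on this are the earlier exchanges of the group on that saturated ring carbon: a number 5 percentage points higher from compound 1 to compound 2 (within the scatter), no change at the digits printed from compound 1 to compound 3 (within the scatter) and a number 5 percentage points lower from compound 2 to compound 3 (within the scatter), none of them beyond the scatter. No step beyond the scatter is therefore expected in this assay. Compound 4 is estimated at 12%, with a range from 3% to 25%. This estimate means an expected step of a number 2 percentage points higher from compound 3 to compound 4 (within the scatter).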

Compound 4, a percentage reported as activity, at one concentration (the size of the read-out at that concentration, not a potency): 20%
The estimate for compound 4 lay 8 percentage points below the measured number; the measured number falls inside the stated range.
By their numbers in this assay, from the lowest: compounds 1, 3, 2 and 4 (each within the scatter of the next).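

In this assay, 4-hydroxyphenyl on the saturated ring carbon gives a number 10 percentage points higher from compound 3 to compound 4 (within the scatter), a number 5 percentage points higher from compound 2 to compound 4 (within the scatter) and a number 10 percentage points higher from compound 1 to compound 4 (within the scatter), all within the scatter. A fourth group at this position, a six-membered aromatic ring of carbon only carrying a hydroxyl, therefore still produces no step beyond the scatter among the compounds shown. No measurement bears on why these steps stay so small.

Going by these compounds, it remains open whether a cyclohexyl group on this ring carbon would give a step beyond the scatter. The same applies to a carboxylic acid or a dimethylamino group on the phenyl ring in place of the hydroxyl.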